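Epimer at the saturated ring carbon: compound 3 to compound 4

This account rests on a few compounds, and the source may have more. Where it says the series, first, only, none or still open, it means among the compounds named here.

Measured so far in a functional assay on the whole organism (strain Lewis) with Rattus norvegicus as the target, with a stated time of 24 h, at a dose of 0.3 mg/kg by the oral route; a lower number here means less inhibition, a higher number more inhibition at the dose given (going by the name of the read-out):
- compound 1, `COc1cccc(COC[C@@H]2CCc3cc([C@H]4CC[C@](N)(CO)C4)ccc3C2)c1`: 40%
- compound 2, `N[C@]1(CO)CC[C@H](c2ccc3c(c2)CC[C@@H](COCc2ccccc2)C3)C1`: 49%
- compound 3, `COc1cccc(OC[C@H]2CCc3cc([C@H]4CC[C@](N)(CO)C4)ccc3C2)c1`: 70%

Compound 3 stands highest of the three numbers in this assay: compound 2 is the nearest, below it beyond the scatter, and compound 1 is the furthest, also beyond the scatter. Among the measured compounds shown here, the one measured step, a number 9 percentage points higher from compound 1 to compound 2 (within the scatter), is a substituent change on an aromatic carbon and lies within the scatter.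

Compound 4, `COc1cccc(OC[C@@H]2CCc3cc([C@H]4CC[C@](N)(CO)C4)ccc3C2)c1`, is not yet measured. It differs from compound 3 as follows: the two compounds have the same atoms and bonds and differ only in configuration as drawn: 1 of 3 stereo elements differ; a stereocentre at a saturated ring carbon is drawn S in compound 3 and R in compound 4. For the measured compounds named here, no measured step changes a configuration, so none bears on this change, and the substituent step between compound 1 and compound 2 gives no guidance on its direction. Since compound 3 is the highest number present, a step of either size is possible, but the headroom above it is smaller than the room below, so the expected step is downward: for compound 4 the estimated step is a number 25 percentage points lower from compound 3 to compound 4 (beyond the scatter). Compound 4 is therefore expected to give about 45% in this assay, within a range from 15% to 75%.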

Compound 4, a percentage reported as inhibition, in the whole organism at one dose (the size of the read-out at that dose, not a potency): 80%
Estimate against measurement, compound 4: 35 percentage points below; the whole stated range lies below it.
By their numbers in this assay, from the lowest: compounds 1 and 2 (each within the scatter of the next); then compounds 3 and 4 (each within the scatter of the next).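

In this assay, the configuration at this saturated ring carbon does not separate the pair, as the step reads a number 10 percentage points higher from compound 3 to compound 4 (within the scatter) and neither drawn form is set apart at this dose. With this configuration held, the group on the oxygen carries the large steps: 3-methoxyphenyl in place of benzyl gives a number 31 percentage points higher from compound 2 to compound 4 (beyond the scatter) and 3-methoxyphenyl in place of 3-methoxybenzyl gives a number 40 percentage points higher from compound 1 to compound 4 (beyond the scatter) in the same assay. The reading of the configuration rests on a clean comparison: the fact that compounds 3 and 4 differ only in the configuration as drawn.

The compounds shown leave open whether the same indifference to configuration holds with benzyl or 3-methoxybenzyl on the oxygen. They also leave open how a nitrile in place of the methoxy, or an amine in place of the oxygen, would read at this dose.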